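The compounds below may be only part of what the source reports. "The series", "measured", "known", "first", "only" and "open" are said of these compounds alone.

Measured so far in a functional assay on HEK293 cells for agonist activity at D(4) dopamine receptor (Homo sapiens), read by FLIPR; on this read-out lower numbers stand for an effect already at smaller amounts and higher numbers for an effect only at larger amounts of compound:
Compound 1, `O=C(CN1CCC(c2cccc[n+]2[O-])CC1)Nc1ccc(F)cc1F`, gives 103 nM.
Compound 2, `O=C(CN1CCC(c2cccc[n+]2[O-])CC1)Nc1ccc(F)cc1`, gives 85 nM.
Compound 3, `O=C(CN1CCC(c2cccc[n+]2[O-])CC1)Nc1ccccc1F`, gives 270 nM.

Compound 3 stands highest of the three in this assay; the steps of a 2.6-fold higher number from compound 1 to compound 3 (0.42 log units; beyond the scatter) and a 3.2-fold higher number from compound 2 to compound 3 (0.50 log units; beyond the scatter) separate it from the others, while a 1.2-fold lower number from compound 1 to compound 2 (0.08 log units; within the scatter) shows no real difference between those two. Compound 4, `Cc1ccc(Cl)cc1NC(=O)CN1CCC(c2cccc[n+]2[O-])CC1`, carries a different aryl group on the amide nitrogen: 5-chloro-2-methylphenyl in place of 2-fluorophenyl on an amide-type nitrogen. Going by the values given here, no measured step replaces a fluoro by chloro or methyl here, so only the modest shifts seen among the three anilides bear on it. Compound 4 is therefore expected to land near compound 3 or somewhat lower, the estimated step being a 1.8-fold lower number from compound 3 to compound 4 (0.26 log units; within the scatter). The estimate for compound 4 in this assay is 150 nM, with a range from 40 nM to 600 nM.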

Compound 4, half-maximal effective concentration: 126 nM
For compound 4 the middle estimate is 1.2-fold (0.08 log units) above the measured one; the measured number falls inside the stated range.
By their numbers in this assay, from the lowest: compounds 2, 1 and 4 (each within the scatter of the next); then compound 3.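

In this assay, 5-chloro-2-methylphenyl on the amide nitrogen, in place of 2-fluorophenyl, gives a 2.1-fold lower number from compound 3 to compound 4 (0.33 log units; beyond the scatter), so this position takes a group with chlorine and a methyl as well as fluorine-bearing rings. Against the other two anilides the same group shows a 1.5-fold higher number from compound 2 to compound 4 (0.17 log units; within the scatter) and a 1.2-fold higher number from compound 1 to compound 4 (0.09 log units; within the scatter), which places compound 4 with compound 1 and compound 2 rather than with compound 3. Nothing available explains the step from 2-fluorophenyl. From the compounds shown here alone, it remains open whether the chloro or the methyl carries this step, since both enter together. Going by these compounds, how a methoxy or trifluoromethyl group, or a plain phenyl, on the amide nitrogen would read also stays open.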